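The compounds below may be only part of what the source reports. "The series", "measured", "known", "first", "only" and "open" are said of these compounds alone.

Measured compounds:
- compound 1 `O=C(Nc1cccc(-n2cc(-c3ccncc3)c(-c3ccc(Cl)c(O)c3)n2)c1)Nc1cccc(C(F)(F)F)c1`: > 32500 nM
- compound 2 `COc1cc(-c2nn(-c3cccc(NC(=O)Nc4cc(C(F)(F)F)cc(C(F)(F)F)c4)c3)cc2-c2ccncc2)ccc1Cl`: 2570 nM

Both were tested in a functional assay on SK-OV-3 cells (Homo sapiens) for inhibition, read by sulforhodamine B assay, with a stated time of 48 h; a higher number here means a weaker inhibitor of growth, a lower number a stronger inhibitor of growth. For compound 1 the entry is not a number but a limit of the assay, (the limit of > 32500 nM in this assay, at which 1 of the 2 values shown sits). For the measured compounds named here, compound 2 is therefore the only compound with a numerical reading; in this assay compound 2 gives 2570 nM, and nothing else on the sheet can be compared with it directly, since compound 1 differs from it in two places at once.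

Compound 3 `O=C(Nc1cccc(-n2cc(-c3ccncc3)c(-c3ccc(Cl)c(O)c3)n2)c1)Nc1cc(C(F)(F)F)cc(C(F)(F)F)c1` has not yet been measured. It keeps the bis-trifluoromethyl urea of compound 2 and changes only one spot: hydrogen in place of methyl on an oxygen on an aromatic ring, that is, methoxy to hydroxy, or 4-chloro-3-methoxyphenyl to 4-chloro-3-hydroxyphenyl. Compound 1 carries the same hydroxy group and sits at the limit, which points to weaker growth inhibition from this change, though compound 1 also differs elsewhere. The step from compound 2 to compound 3 is expected to be a loss of potency beyond the usual scatter, a 3.1-fold higher number from compound 2 to compound 3 (0.49 log units; beyond the scatter). Compound 3 is estimated at 8000 nM, within 2500 nM to 40000 nM.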

Compound 3, concentration for total growth inhibition: 3810 nM
Estimate against measurement, compound 3: 2.1-fold (0.32 log units) above, within the range that was stated.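

In this assay, the step at this position is small: a 1.5-fold higher number from compound 2 to compound 3 (0.17 log units; within the scatter). With the bis-trifluoromethyl urea held fixed, 4-chloro-3-hydroxyphenyl and 4-chloro-3-methoxyphenyl therefore cannot be told apart in this growth test, so the hydroxy group alone does not go with a loss of potency, as compound 1 had seemed to suggest. Compound 1 carries the same hydroxy group, and its entry is a limit, not a number: the limit of > 32500 nM in this assay, at which 1 of the 3 values shown sits. Between the two hydroxy compounds, the single change is trifluoromethyl in place of hydrogen on an aromatic carbon, and it comes with a clear gain, an at least 8.5-fold lower number from compound 1 to compound 3 (0.93 log units; beyond the scatter), so the urea side, not the oxygen substituent, is the place that matters among these compounds.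

Only hydrogen and methyl on this oxygen are shown, so it remains open whether a longer chain such as ethyl or butyl, or an amine in place of the oxygen, would keep the reading. As far as these compounds go, it also remains open whether methoxy and hydroxy would read alike on the urea of compound 1, whose limit offers no number to compare.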